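Acyl group exchange on compound 1: working notes

The source may report more compounds than this note shows. Statements on the series, on what has been measured and on what is new or still open speak of the compounds shown alone.

Values in a functional assay on A549 cells (Homo sapiens) for cytotoxicity, read by MTT assay, with a stated time of 48 h (on this read-out higher numbers stand for weaker inhibition and lower numbers for stronger inhibition), for the measured members of the series:
- compound 1 `COc1cc(-c2nnc3n2NC(c2ccco2)C(C(=O)c2ccc(F)cc2)S3)cc(OC)c1OC`: 53700 nM
- compound 2 `COc1cc(-c2nnc3n2NC(c2cccs2)C(C(=O)c2ccc(C)cc2)S3)cc(OC)c1OC`: 12700 nM
- compound 3 `COc1cc(-c2nnc3n2NC(c2cccs2)C(C(=O)c2ccc(Cl)cc2)S3)cc(OC)c1OC`: 20100 nM

Compound 1 gives the highest number of the three. Compound 3 stands nearest to it and compound 2 furthest, both gaps beyond the scatter, so compound 1 is the weakest inhibitor measured so far.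

Compound 4 `COc1cc(-c2nnc3n2NC(c2ccco2)C(C(=O)c2ccco2)S3)cc(OC)c1OC` differs from compound 1 by furan-2-yl in place of 4-fluorophenyl on a carbonyl carbon; cut one bond further out, the difference reads (4-fluorophenyl)carbonyl to (furan-2-yl)carbonyl.

Going by the values given here, no measured pair isolates this change. Among the compounds with values here, the only single-point step, a 1.6-fold higher number from compound 2 to compound 3 (0.20 log units; within the scatter), concerns the substituent on an aromatic carbon of the aroyl group and is within the scatter. Compounds 2 and 3 differ from compound 1 in two places at once, so what the furan-2-yl group does on the carbonyl carbon cannot be read from them.

Within the data shown here, with no bearing step, the expectation for compound 4 is a step of a 1.2-fold lower number from compound 1 to compound 4 (0.08 log units; within the scatter), that is, none beyond the scatter from compound 1, with the range widened for the missing evidence. Compound 4 is estimated at 45000 nM, between 18000 nM and 110000 nM.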

Compound 4, half-maximal inhibitory concentration: 68700 nM
Compound 4: the middle estimate sits 1.5-fold (0.18 log units) below what was measured; the measured number falls inside the stated range.
By their numbers in this assay, from the lowest: compounds 2 and 3 (each within the scatter of the next); then compounds 1 and 4 (each within the scatter of the next).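

In this assay, the exchange on the carbonyl carbon now has a measured pair of its own, and a 1.3-fold higher number from compound 1 to compound 4 (0.11 log units; within the scatter) leaves compounds 1 and 4 within the scatter of each other. A six-membered aromatic ring of carbon only and a five-membered aromatic ring with a hetero atom therefore read alike at this position, at least with the rest of compound 1 unchanged, a finding that the substituent step a 1.6-fold higher number from compound 2 to compound 3 (0.20 log units; within the scatter) could not give, as it kept the aromatic ring in place. No measurement to hand gives any account of this result.

On these data alone, compounds 2 and 3 differ from compound 1 in two places, so the same exchange remains untested with the ring that they carry in place of the furan-2-yl group on the core. Also open, as far as these compounds go, is whether a carboxylic acid or an amine on the aromatic ring of the acyl group, or a longer alkyl chain in place of that ring on the carbonyl carbon, would move the number beyond the scatter.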